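Moving a Trifluoromethyl Group on a Weakly Active Scaffold

A few compounds are considered here, and "the series" means these few. Any claim that something is new, unique, unknown or untested is made for them only; others in the source may bear on it.

Compound 1, `Oc1cccc(-c2cc(-c3ccccc3C(F)(F)F)cc(-c3cccc(O)c3)n2)c1`, gives 4350 nM in a functional assay on T47D cells (Homo sapiens) for inhibition; on this read-out higher numbers stand for weaker inhibition and lower numbers for stronger inhibition.
Compound 2, `Oc1cccc(-c2cc(-c3cccc(C(F)(F)F)c3)cc(-c3cccc(O)c3)n2)c1`, gives 4970 nM in this assay.
Compound 3, `Oc1ccc(-c2cc(-c3ccccc3C(F)(F)F)cc(-c3ccc(O)cc3)n2)cc1`, gives > 50000 nM in this assay, which is a limit of the assay and not a number.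

Compound 1 and compound 2 share a core and differ in one place: 3-(trifluoromethyl)phenyl in place of 2-(trifluoromethyl)phenyl on an aromatic carbon. This change made a step of a 1.1-fold higher number from compound 1 to compound 2 (0.06 log units; within the scatter), so the two compounds cannot be told apart on this read-out.

Compound 3 carries a different core; how it differs from the core of compound 1 is not broken down here. For compound 3 the assay gave only a limit (the limit of > 50000 nM in this assay, at which 1 of the 3 values shown sits), so inhibition was too weak to be measured as a number.

Compound 4, `Oc1ccc(-c2cc(-c3cccc(C(F)(F)F)c3)cc(-c3ccc(O)cc3)n2)cc1`, has not yet been measured. It stands to compound 3 as compound 2 stands to compound 1: 3-(trifluoromethyl)phenyl in place of 2-(trifluoromethyl)phenyl on an aromatic carbon. The two places are not identical, since in compound 1 the group sits meta to two 3-hydroxyphenyl groups and in compound 3 meta to two 4-hydroxyphenyl groups, so this is the same kind of change rather than the same change.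

Because the step of a 1.1-fold higher number from compound 1 to compound 2 (0.06 log units; within the scatter) stayed within the scatter, the step from compound 3 to compound 4 is expected to be small as well, estimated at a step that the limit leaves unreadable from compound 3 to compound 4. Compound 4 is therefore expected to give about 60000 nM, with a range of 20000 nM to 200000 nM, and most likely the assay would again report only a limit.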

Compound 4, half-maximal inhibitory concentration: > 50000 nM
Compound 4 gave a limit, no number (the forecaster's own chance of this, stated with the estimate: 75%); the middle value is on the limit's open side.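

In this assay compound 4, like compound 3, gives only a limit and not a number: the limit of > 50000 nM in this assay, at which 2 of the 4 values shown sit. With two limits, no size can be read for the step between compound 3 and compound 4. The compounds shown leave open whether 3-(trifluoromethyl)phenyl in place of 2-(trifluoromethyl)phenyl changes inhibition at all on the core of compound 3.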